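The source may hold more compounds than are shown below. What is called first, only, known or untested is meant among the compounds shown, and "the series" means these compounds.

Going by the values given here, in an ADME assay on BaF3 cells (Mus musculus) for antiproliferative activity, read by CCK-8 assay, with a stated time of 72 h (on this read-out lower numbers stand for stronger inhibition of growth and higher numbers for weaker inhibition of growth), only two compounds have numbers so far. Compound 1 `Cc1n[nH]c2cc(SCCC(=O)Nc3ccc(CN4CCN(C)CC4)c(C(F)(F)F)c3)ccc12` gives 3900 nM and compound 2 `CN1CCN(Cc2ccc(NC(=O)CCSc3ccc4c(-c5ccccc5)n[nH]c4c3)cc2C(F)(F)F)CC1` gives 600 nM as the lower of the two numbers. Compound 3 `CN1CCN(Cc2ccc(NC(=O)CCSc3ccc4c(-c5ccncc5)n[nH]c4c3)cc2C(F)(F)F)CC1` differs from compound 2 in a single group, and that difference is pyridin-4-yl in place of phenyl on an aromatic carbon in full. In words, pyridin-4-yl stands in place of phenyl on an aromatic carbon of a five-membered aromatic ring with 2 nitrogen. Among the compounds with values here, one measured step touches that same carbon, where phenyl came in place of methyl. That step, a 6.5-fold lower number from compound 1 to compound 2 (0.81 log units; beyond the scatter) and modest in size though beyond the scatter, brought in a whole ring, whereas here one six-membered aromatic ring replaces another. A smaller step is therefore expected, and the data give only a weak hint of its direction, so a slightly lower number is a tentative guess. The expected change is a 1.5-fold lower number from compound 2 to compound 3 (0.18 log units; within the scatter) and is estimated to stay within the scatter. In this assay the estimated value for compound 3 is 400 nM with an expected range from 120 nM to 1500 nM for now.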

Compound 3, concentration for 50% growth inhibition: 1060 nM
Beside the measured number, compound 3's estimate is 2.7-fold (0.42 log units) below it, within the range that was stated.
By their numbers in this assay, from the lowest: compounds 2 and 3 (each within the scatter of the next); then compound 1.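

In this assay, pyridin-4-yl in place of phenyl on this aromatic carbon gives a 1.8-fold higher number from compound 2 to compound 3 (0.25 log units; within the scatter), so this read-out does not separate the two rings, even though pyridin-4-yl carries one hydrogen-bond acceptor and phenyl carries none. Pyridin-4-yl in place of methyl gives a 3.7-fold lower number from compound 1 to compound 3 (0.57 log units; beyond the scatter), which shows that the difference from methyl at this carbon is not unique to phenyl: a six-membered aromatic ring with one hetero atom also stands apart from methyl. No measured evidence is available to explain either step.

Still open, from the compounds shown here alone, is whether the position of the ring nitrogen matters, which pyridin-3-yl or pyridin-2-yl could test at this same carbon. It is also unclear whether this carbon needs an aromatic ring at all, a question that a saturated ring such as piperidine or a small group such as an amine could address.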